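This account rests on a few compounds, and the source may have more. Where it says the series, first, only, none or still open, it means among the compounds named here.

In a functional assay on HeLa cells (Homo sapiens) for antiproliferative activity, read by CCK-8 assay, with a stated time of 72 h (a lower number here means a stronger inhibitor, a higher number a weaker inhibitor), compound 1 `CCc1ccc(SCc2ccc(C(=O)Nc3ccccc3N)cc2)cc1` gives 3800 nM and compound 2 `Cc1ccc(SCc2ccc(C(=O)Nc3ccccc3N)cc2)cc1` gives 4250 nM while compound 3 `Nc1ccccc1NC(=O)c1ccc(CSc2ccc(F)cc2)cc1` gives 5010 nM so compound 3 stands within the scatter of both others. Compound 4 `Nc1ccccc1NC(=O)c1ccc(CSc2ccc(Cl)cc2)cc1` differs from compound 3 by chloro in place of fluoro on an aromatic carbon with chloro in place of fluoro on an aromatic carbon. Going by the values given here, two measured steps bear on that same place: a 1.2-fold higher number from compound 2 to compound 3 (0.07 log units; within the scatter) and a 1.3-fold higher number from compound 1 to compound 3 (0.12 log units; within the scatter) and both are small. No step beyond the scatter is therefore expected in this assay and the estimated change is a 1.1-fold lower number from compound 3 to compound 4 (0.05 log units; within the scatter) at most a working figure. For compound 4 the estimated value is 4500 nM with an expected range from 2200 nM to 9000 nM in this assay.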

Compound 4, half-maximal inhibitory concentration: 12700 nM
Compound 4: the middle estimate sits 2.8-fold (0.45 log units) below what was measured, outside the stated range (above it).
By their numbers in this assay, from the lowest: compounds 1, 2 and 3 (each within the scatter of the next); then compound 4.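

In this assay, going by these compounds alone, chloro is the first group at this position to move the number beyond the scatter (a 2.5-fold higher number from compound 3 to compound 4 (0.40 log units; beyond the scatter)), (a 3.0-fold higher number from compound 2 to compound 4 (0.48 log units; beyond the scatter)) and (a 3.3-fold higher number from compound 1 to compound 4 (0.52 log units; beyond the scatter)). Fluoro, methyl and ethyl had stayed within the scatter of each other, so the position is not indifferent to what it carries, and the swap of one halogen for another is enough to show this. Nothing available explains why chloro stands apart from these three groups.

Going by these compounds, whether bromo would follow chloro or stay with fluoro remains open. So does the direction in which an amine or a carboxylic acid at this place would move the number.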